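Swapping a Pyridine for a Thiophene on a Shared Core

The source may hold more compounds than are shown below. What is called first, only, known or untested is meant among the compounds shown, and "the series" means these compounds.

Measured so far in an assay on isolated protein for inhibition of DNA topoisomerase 1 (Homo sapiens), with a stated time of 30 min, tested at 100 uM; a lower number here means a weaker effect, a higher number a stronger effect of the compound at the concentration tested:
Compound 1 `Oc1ccc(-c2cc(-c3ccccn3)nc(-c3ccccc3Cl)c2)cc1` gives 5.2%.
Compound 2 `Oc1cccc(-c2cc(-c3ccncc3)nc(-c3cccc(Cl)c3)c2)c1` gives 0%.
Compound 3 `Oc1ccc(-c2cc(-c3cccc(Cl)c3)nc(-c3ccccn3)c2)cc1` gives 59.4%.

Compound 1 stands second highest of the three numbers, close to compound 2 and within the scatter of it, but far from compound 3: a number 54.2 percentage points higher from compound 1 to compound 3 (beyond the scatter). Compound 4 `Oc1ccc(-c2cc(-c3ccsc3)nc(-c3ccccc3Cl)c2)cc1` differs from compound 1 in one place: thiophen-3-yl in place of pyridin-2-yl on an aromatic carbon. Among the measured compounds shown here, the only measured step concerns a change of the chlorophenyl group, not the pyridin-2-yl, so no measured step bears on this exchange, and the data give no ground to expect a step beyond the scatter. For compound 4 the expected value is 8%, within a range of 0% to 30%, which means an expected step of a number 2.8 percentage points higher from compound 1 to compound 4 (within the scatter).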

Compound 4, a percentage reported as inhibition, at one concentration (the size of the read-out at that concentration, not a potency): 4.1%
Estimate against measurement, compound 4: 3.9 percentage points above, within the range that was stated.
By their numbers in this assay, from the lowest: compounds 2, 4 and 1 (each within the scatter of the next); then compound 3.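

Placing thiophen-3-yl, a five-membered aromatic ring, where pyridin-2-yl stood, next to the ring nitrogen, gives a number 1.1 percentage points lower from compound 1 to compound 4 (within the scatter) in this assay. With the 2-chlorophenyl group present, the pyridine nitrogen is therefore not needed at this position to keep the read-out where it was, although both numbers are low, so a loss would be hard to see. Nothing measured here gives a reason for this result.

As far as these compounds go, whether thiophen-3-yl would hold up alongside the 3-chlorophenyl group of compound 3, which gives 59.4%, remains open. So does the effect of an amine or a carboxylic acid at this position.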